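The compounds below may be only part of what the source reports. "The series", "measured", "known", "first", "only" and "open" are said of these compounds alone.

In a functional assay on Raji cells (Homo sapiens) for inhibition, read by MTT assay, with a stated time of 72 h (on this read-out lower numbers stand for stronger inhibition and higher numbers for weaker inhibition), three compounds have been measured so far. Compound 1 `CO[C@@H]1[C@H]2OC(=O)C[C@H]2O[C@@H]1[C@@H](O)c1ccccc1` gives 12200 nM, and compound 3 `CO[C@@H]1[C@H]2OC(=O)C[C@H]2O[C@@H]1C(O)(c1ccccc1)c1ccccc1` gives 19000 nM. These two values lie within the usual scatter of each other, so they cannot be told apart and together form the upper end of the numbers. Compound 2 `O=C1C[C@H]2O[C@H](C(O)O)[C@H](O)[C@H]2O1` gives 1250 nM, a clearly lower number than compound 1 shows, which means stronger inhibition.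

The next compound to consider is compound 4 `CO[C@@H]1[C@H]2OC(=O)C[C@H]2O[C@@H]1[C@H](O)c1ccccc1`, which has the same atoms and bonds as compound 1 and differs only in its spatial arrangement: the two compounds have the same atoms and bonds and differ only in configuration as drawn: 1 of 5 stereo elements differ; a stereocentre at a saturated chain carbon is drawn S in compound 1 and R in compound 4. Among the compounds with values here, no measured pair here differs by configuration alone, so the data do not show how much such a change matters. With nothing pointing either way, the expectation is a step no larger than the scatter in this assay, with no firm direction. The estimated change is a 1.2-fold lower number from compound 1 to compound 4 (0.09 log units; within the scatter). For compound 4 the expected value is 10000 nM, with an estimated range from 3500 nM to 28000 nM.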

Compound 4, half-maximal inhibitory concentration: 8690 nM
For compound 4 the middle estimate is 1.2-fold (0.06 log units) above the measured one, and the stated range covers the measured number.
By their numbers in this assay, from the lowest: compound 2; then compounds 4, 1 and 3 (each within the scatter of the next, the first and the last beyond it).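

Within the data shown here, compounds 1 and 4 are the first pair here that differ in one place only, so they give the first direct reading of what a change of configuration does. In this assay, turning a stereocentre at a saturated chain carbon from S to R gives a 1.4-fold lower number from compound 1 to compound 4 (0.15 log units; within the scatter), so the two forms cannot be told apart on this read-out. The comparison is a clean one because nothing else separates the pair: the fact that compounds 1 and 4 differ only in the configuration as drawn.

Still open, on these data alone, is how the other stereo elements behave, and whether an amine or a carboxylic acid in place of the phenyl ring would shift the number more than this change of configuration does. Compound 2 differs from the others in more than one place, so its 1250 nM is not yet tied to any single change.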